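The source may hold more compounds than are shown below. What is called first, only, known or untested is meant among the compounds shown, and "the series" means these compounds.

In an ADME assay on Raji cells (Homo sapiens) for cytotoxicity, read by CellTiter-Glo and resazurin assay, with a stated time of 72 h (a lower number here means that less compound is needed, a higher number that more compound is needed for the effect), compound 1 `CC(=O)Nc1cccc(-c2ccc(C(=O)N(Cc3cccc(OCCCCCC(=O)O)c3)C(C)C)cc2)c1` gave only a limit, > 26000 nM. Compound 2 `CCOC(=O)CCCCCOc1cccc(CN(C(=O)c2ccc(-c3ccc(C(C)=O)s3)cc2)C(C)C)c1` likewise reached only a limit in this assay, > 26000 nM. Both values sit at the limit of > 26000 nM in this assay, at which 2 of the 2 values shown sit, so compound 2 stands at the edge of what this assay resolves, with no number to place it above or below its neighbour. Compound 3 `CCOC(=O)CCCCCOc1cccc(CN(C(=O)c2ccc(-c3ccc(Cl)c(Cl)c3)cc2)C(C)C)c1` differs from compound 2 by 3,4-dichlorophenyl in place of 5-acetylthiophen-2-yl on an aromatic carbon. Going by the values given here, with no measured step to guide the expectation, the step that the limit leaves unreadable from compound 2 to compound 3 is expected to stay within the scatter, the limit most likely being reached again. Compound 3 is therefore estimated at 30000 nM, within a range of 8000 nM to 120000 nM.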

Compound 3, half-maximal effective concentration: > 26000 nM
Compound 3 was reported as a limit (the forecaster's own chance of this, stated with the estimate: 75%); the middle value does not contradict the limit.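

Compound 2 and compound 3 are both reported only as limits, so no step can be read between them: the limit of > 26000 nM in this assay, at which 3 of the 3 values shown sit. The compounds shown leave open whether 3,4-dichlorophenyl and 5-acetylthiophen-2-yl differ at all in this assay.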